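A few compounds are considered here, and "the series" means these few. Any claim that something is new, unique, unknown or untested is made for them only; others in the source may bear on it.

Measured compounds in an ADME assay on cells (Macrophage, Homo sapiens) for cytotoxicity, read by MTT assay, with a stated time of 24 h; on this read-out lower numbers stand for higher toxicity in this test and higher numbers for lower toxicity in this test:
compound 1 `COc1ccc(/C=C/c2ncc([N+](=O)[O-])n2CC(C)O)cc1` gives 560 nM
compound 2 `CC(O)Cn1c([N+](=O)[O-])cnc1/C=C/c1ccc([N+](=O)[O-])cc1` gives 410 nM
compound 3 `Cc1ccc(/C=C/c2ncc([N+](=O)[O-])n2CC(C)O)cc1` gives 860 nM

Compound 3 shows the highest number of the three in this assay, though only the gap to compound 2 is beyond the scatter: a 2.1-fold higher number from compound 2 to compound 3 (0.32 log units; beyond the scatter). The other two gaps are a 1.5-fold higher number from compound 1 to compound 3 (0.19 log units; within the scatter) and a 1.4-fold lower number from compound 1 to compound 2 (0.14 log units; within the scatter).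

The next compound is compound 4 `CC(O)Cn1c([N+](=O)[O-])cnc1/C=C/c1ccc(N(C)C)cc1`. Relative to compound 3 the change is dimethylamino in place of methyl on an aromatic carbon. Within the data shown here, no measured step brings in a dimethylamino group, so the bearing steps are indirect: the exchanges among methoxy, nitro and methyl at the same position moved this assay by small amounts, at most by the modest step from compound 2 to compound 3. A change of the group at this position is therefore expected to give no step beyond the scatter, in either direction, from compound 3. For compound 4 the estimated number in this assay is 700 nM (range 300 nM to 1600 nM). The expected step from compound 3 is then a 1.2-fold lower number from compound 3 to compound 4 (0.09 log units; within the scatter).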

Compound 4, half-maximal cytotoxic concentration: 680 nM
The estimate for compound 4 lay 1.0-fold (0.01 log units) above the measured number; the measured number falls inside the stated range.
By their numbers in this assay, from the lowest: compounds 2, 1, 4 and 3 (each within the scatter of the next, the first and the last beyond it).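

In this assay, dimethylamino joins methoxy, nitro and methyl on this aromatic carbon, para to a large group, and all three of its exchanges stay within the scatter: a 1.3-fold lower number from compound 3 to compound 4 (0.10 log units; within the scatter), a 1.7-fold higher number from compound 2 to compound 4 (0.22 log units; within the scatter) and a 1.2-fold higher number from compound 1 to compound 4 (0.08 log units; within the scatter). Replacing methyl, with 1 heavy atom and 0 hydrogen-bond acceptors, by a group with 3 heavy atoms and 1 hydrogen-bond acceptor therefore gives no step beyond the scatter, and the step between compound 2 and compound 3 remains the only one that is. Nothing available explains why these numbers stay so close.

Open, as far as these compounds go, is whether a carboxylic acid, a primary amine or a longer alkyl chain at this position would also stay within the scatter. Also open, from the compounds shown here alone, is how the numbers respond when the hydroxyl-bearing side chain of the shared core is replaced, for example by a simple ethyl chain.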